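From 2-fluorobenzyl to 3-fluorobenzyl in compound 3

The source may hold more compounds than are shown below. What is called first, only, known or untested is meant among the compounds shown, and "the series" means these compounds.

Results so far in a functional assay on aorta (Rattus norvegicus, strain Sprague-Dawley) (on this read-out higher numbers stand for an effect only at larger amounts of compound and lower numbers for an effect already at smaller amounts), are these
Compound 1 `Cc1nn(-c2ccccc2)c2nc(O)c(-c3nc(N)cc(N)n3)cc12` has the entry "not determined" (no result reported)
Compound 2 `Cc1ccccc1COc1nc2c(cc1-c1nc(N)cc(N)n1)c(C)nn2-c1ccccc1` gives 290 nM
Compound 3 `Cc1nn(-c2ccccc2)c2nc(OCc3ccccc3F)c(-c3nc(N)cc(N)n3)cc12` gives 2200 nM

Of the two numbers available, compound 3 holds the higher one at 2200 nM and compound 2 the lower one at 290 nM while compound 1 offers no number for comparison. Compound 4 `Cc1nn(-c2ccccc2)c2nc(OCc3cccc(F)c3)c(-c3nc(N)cc(N)n3)cc12` has not yet been measured. It keeps the shared core of compound 3 and differs from it by 3-fluorophenyl in place of 2-fluorophenyl on a saturated chain carbon bound to an oxygen on an aromatic ring in a swap of 3-fluorophenyl in place of 2-fluorophenyl on a saturated chain carbon bound to an oxygen on an aromatic ring.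

Among the compounds with values here, only one measured step bears on this change, and only indirectly. It is a 7.6-fold higher number from compound 2 to compound 3 (0.88 log units; beyond the scatter) and it places fluoro where methyl stood on an aromatic carbon. Within the data shown here, no measured step shows what happens when the fluoro itself moves, so the data support neither direction. The expected step is a 1.2-fold lower number from compound 3 to compound 4 (0.09 log units; within the scatter) and it is estimated to stay within the size of that one measured step. Compound 4 is estimated at 1800 nM with an expected range from 500 nM to 6500 nM when it is measured.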

Compound 4, half-maximal effective concentration: 360 nM
Compound 4: the middle estimate sits 5.0-fold (0.70 log units) above what was measured; the measured number lies below the stated range.
By their numbers in this assay, from the lowest: compounds 2 and 4 (each within the scatter of the next); then compound 3.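

In this assay, the place of the fluoro on the benzyl group proves to count: 2-fluorobenzyl and 3-fluorobenzyl have the same atoms, yet the swap gives a 6.1-fold lower number from compound 3 to compound 4 (0.79 log units; beyond the scatter) on the saturated chain carbon bound to an oxygen on an aromatic ring, a step beyond the scatter and close in size to the earlier one from methyl to fluoro. The earlier pair could be read as saying that fluoro on this benzyl group goes with a higher number than methyl, but that reading holds only for 2-fluorobenzyl, since 3-fluorophenyl in place of 2-methylphenyl gives a 1.2-fold higher number from compound 2 to compound 4 (0.09 log units; within the scatter) and so stays within the scatter. Nothing available explains why moving the fluoro has this size of effect in this series.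

The compounds shown leave open how a plain benzyl group without any fluoro or methyl would compare with these three. They also leave open whether a longer chain between the oxygen and the phenyl ring, or an amine on that ring in place of the fluoro, would be tolerated on this read-out.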